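A few compounds are considered here, and "the series" means these few. Any claim that something is new, unique, unknown or untested is made for them only; others in the source may bear on it.

Measured so far:
compound 1 `CCN(CC)CCCOc1cc2ncnc(Nc3nc4ccc(C(=O)Nc5c(C)cccc5Cl)cc4s3)c2cc1OC`: 11700 nM
compound 2 `COc1cc2c(Nc3nc4ccc(C(=O)Nc5c(C)cccc5C)cc4s3)ncnc2cc1OCCCN1CCCC1`: > 100000 nM

Among the compounds with values here, in a functional assay on DLD-1 cells (Homo sapiens) for cytotoxicity, read by WST assay, with a stated time of 72 h (on this read-out higher numbers stand for weaker inhibition and lower numbers for stronger inhibition), compound 1 gives 11700 nM, the only number in the set so far. Compound 2 in this assay gives > 100000 nM, which is a limit and not a number (the limit of > 100000 nM in this assay, at which 1 of the 2 values shown sits). Compound 1 and compound 2 differ in more than one place, so their two values show no more than that compound 1 yields a number where compound 2 does not.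

Compound 3 `COc1cc2c(Nc3nc4ccc(C(=O)Nc5c(C)cccc5Cl)cc4s3)ncnc2cc1OCCCN1CCCCC1` is not yet measured in this assay. Against compound 1 the change is: piperidin-1-yl in place of diethylamino on a saturated chain carbon, three bonds along the chain from an oxygen on an aromatic ring. Within the data shown here, no measured pair isolates this change, so nothing in the set fixes its size or direction. The step from compound 1 to compound 3 is expected to be small, within the scatter of this assay, in no set direction a 1.0-fold higher number from compound 1 to compound 3 (0.01 log units; within the scatter). Compound 3 is estimated at 12000 nM in this assay, with a range from 4000 nM to 40000 nM.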

Compound 3, half-maximal inhibitory concentration: 14700 nM
Compound 3: the middle estimate sits 1.2-fold (0.09 log units) below what was measured, and the stated range covers the measured number.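

In this assay, exchanging diethylamino for piperidin-1-yl on a saturated chain carbon, three bonds along the chain from an oxygen on an aromatic ring, gives a 1.3-fold higher number from compound 1 to compound 3 (0.10 log units; within the scatter). Within the data shown here, this is the first pair that isolates a change at this position, and it shows that the open diethylamino group and the six-membered piperidin-1-yl ring cannot be told apart here. No measured property in the set bears on this step.

Among these compounds, compound 2 gives > 100000 nM, which is a limit and not a number, and it differs from compound 1 and compound 3 in more than one place, so no step to it can be read. From the compounds shown here alone, whether morpholin-4-yl or 4-methylpiperazin-1-yl in the same place, or a chain longer than propyl, would stay within the scatter of these two values remains open.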